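A few compounds are considered here, and "the series" means these few. Any claim that something is new, unique, unknown or untested is made for them only; others in the source may bear on it.

Working notes on the series, read in an ADME assay on HT-29 cells (Homo sapiens) for cytotoxicity, read by luminescence and CellTiter-Glo, with a stated time of 10 h; a lower number here means that less compound is tolerated, a higher number that more compound is tolerated. Of the compounds shown here, two have been measured so far. Compound 1 `CN1C(=S)[C@H](NC(=O)c2n[nH]c(Cc3ccccc3)n2)COc2ccccc21`, entered twice, gives > 50000 nM; > 50000 nM (2 entries), which is a limit of the assay and not a number. Compound 2 `O=C(N[C@H]1COc2ccccc2NC1=S)c1n[nH]c(Cc2ccccc2)n1` gives > 50000 nM, which is likewise a limit, so compound 2 has no single number to start from. For the measured compounds named here, no step between measured compounds is available either.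

Compound 3 `O=C(N[C@@H]1COc2ccccc2NC1=S)c1n[nH]c(Cc2ccccc2)n1` is the next to be read. Its relation to compound 2 is simple: the two compounds have the same atoms and bonds and differ only in configuration as drawn: 1 of 1 stereo elements differ; a stereocentre at a saturated ring carbon is drawn S in compound 2 and R in compound 3. The two compounds have the same atoms and bonds, and only a stereocentre at a saturated ring carbon differs, drawn S in compound 2 and R in compound 3.

No step beyond the usual scatter is expected in this assay, in either direction, and a further limit reading is the likeliest result. This expectation rests only on compound 2 giving the limit > 50000 nM.

The expected step is a number no higher from compound 2 to compound 3 (the limit leaves the size open). For compound 3 the estimated value is 50000 nM, with an expected range from 25000 nM to 100000 nM.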

Compound 3, half-maximal cytotoxic concentration: > 50000 nM
Compound 3: a limit, no number; the forecaster's own chance of this, stated with the estimate: 85%; the middle value lies on the limit itself.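

In this assay no step can be read between compound 2 and compound 3: each reading is a limit of the assay and not a number. The compounds shown leave open whether the configuration at the saturated ring carbon makes any difference to the tolerated concentration; none of the three compounds gives a single number.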